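The source may report more compounds than this note shows. Statements on the series, on what has been measured and on what is new or still open speak of the compounds shown alone.

In a functional assay on SW 1116 cells (Homo sapiens) for antiproliferative activity, read by MTT assay, with a stated time of 48 h; on this read-out higher numbers stand for weaker inhibition and lower numbers for stronger inhibition:
- compound 1 `Clc1cccc(CSc2nnc(-c3cnccn3)n2-c2ccccc2)c1`: 6610 nM
- compound 2 `Brc1cccc(CSc2nnc(-c3cnccn3)n2-c2ccccc2)c1`: 5030 nM
- compound 3 `Fc1ccc(CSc2nnc(-c3cnccn3)n2-c2ccccc2)cc1`: 4120 nM

At 4120 nM, compound 3 cannot be separated from the other two: a 1.6-fold lower number from compound 1 to compound 3 (0.21 log units; within the scatter) and a 1.2-fold lower number from compound 2 to compound 3 (0.09 log units; within the scatter) both lie within the usual scatter of repeat measurements.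

Compound 4 `Fc1cccc(F)c1CSc1nnc(-c2cnccn2)n1-c1ccccc1` differs from compound 3 on a saturated chain carbon bound to a sulfur: 2,6-difluorophenyl in place of 4-fluorophenyl on a saturated chain carbon bound to a sulfur. There, 2,6-difluorophenyl takes the place of 4-fluorophenyl.

Those two steps changed the group at this same place and stayed small, as did a 1.3-fold lower number from compound 1 to compound 2 (0.12 log units; within the scatter). Going by the values given here, no measured compound carries the 2,6-difluorophenyl group, so this rests on limited evidence. The expected change in this assay is a 1.1-fold higher number from compound 3 to compound 4 (0.04 log units; within the scatter), which means no step beyond the scatter. For compound 4 the estimated value is 4500 nM, with an expected range from 2000 nM to 10000 nM.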

Compound 4, half-maximal inhibitory concentration: 24100 nM
Estimate against measurement, compound 4: 5.4-fold (0.73 log units) below, outside the stated range (above it).
By their numbers in this assay, from the lowest: compounds 3, 2 and 1 (each within the scatter of the next); then compound 4.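

In this assay, the group on the saturated chain carbon bound to a sulfur clearly can matter: with 2,6-difluorophenyl there is a 5.8-fold higher number from compound 3 to compound 4 (0.77 log units; beyond the scatter) and also a 4.8-fold higher number from compound 2 to compound 4 (0.68 log units; beyond the scatter) and a 3.6-fold higher number from compound 1 to compound 4 (0.56 log units; beyond the scatter) at this same place. Going by these compounds alone, the 3-chlorophenyl, 3-bromophenyl and 4-fluorophenyl groups had stayed within the scatter of one another, so these are the first steps here to go beyond it. Nothing shown explains this weaker inhibition.

The compounds shown leave open whether 2-fluorophenyl or 2,6-dichlorophenyl would give a similarly high number. They also leave open how a cyclohexyl group would fare at this place.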